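Swapping a methylsulfanyl for a bicyclic amine

This account rests on a few compounds, and the source may have more. Where it says the series, first, only, none or still open, it means among the compounds named here.

Among the compounds with values here, in an assay on Sf21 cells for inhibition of mitogen-activated protein kinase kinase kinase 13 (Homo sapiens), read by HTRF, with a stated time of 1.5 h (a lower number here means a stronger inhibitor, a higher number a weaker inhibitor), compound 2 `CCOC(=O)N1C[C@@H]2C[C@H]1CN2c1nc(SC)cc(-c2cnc(N)c(OC(F)F)n2)n1` gives 44 nM, the lowest of the two numbers known so far. Within the data shown here, compound 1 `Nc1cnc(-c2cc(N3C[C@@H]4C[C@H]3CO4)nc(N3CC4CC3C4)n2)cn1` gives 247 nM in this assay; no single-point step links it to compound 2, so only the two values stand side by side. Compound 3 `CCOC(=O)N1C[C@@H]2C[C@H]1CN2c1nc(-c2cnc(N)c(OC(F)F)n2)cc(N2CC3CC2C3)n1` awaits measurement; it differs from compound 2 in that (a group of 6 heavy atoms (5 carbon, 1 nitrogen; one four-membered non-aromatic ring of carbon only, one five-membered non-aromatic ring with 1 hetero atom) in place of a group of 2 heavy atoms (1 carbon, 1 sulfur; no ring), on an aromatic carbon). Among the measured compounds shown here, no measured pair tracks this exchange, so the expected step is modest and could go either way: a 1.4-fold higher number from compound 2 to compound 3 (0.13 log units; within the scatter). Compound 3 is therefore estimated at 60 nM, within 15 nM to 250 nM.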

Compound 3, half-maximal inhibitory concentration: 13 nM
Compound 3: middle estimate off by 4.6-fold (0.66 log units), on the high side, and the stated range ends above it.
By their numbers in this assay, from the lowest: compound 3; then compound 2; then compound 1.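

In this assay the position on an aromatic carbon next to the ring nitrogen accepts a far bulkier group than methylsulfanyl, and the bicyclic amine gives a 3.4-fold lower number from compound 2 to compound 3 (0.53 log units; beyond the scatter) and so a real gain beyond the scatter. The earlier compounds shown here offered no matched pair to show this. No available evidence bears on what lies behind the gain.

One exchange cannot separate the effect of the bicycle from that of any amine at this position. A dimethylamine, a pyrrolidine or a morpholine in the same place would tell these apart.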